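A few compounds are considered here, and "the series" means these few. Any claim that something is new, unique, unknown or untested is made for them only; others in the source may bear on it.

Measured in an assay on Cerebral cortex for binding affinity to adenosine receptor A1 (Cavia porcellus), read by radioligand binding; on this read-out higher numbers stand for weaker inhibition and lower numbers for stronger inhibition:
Compound 1 `CCCn1c(=O)n(CC(C)=O)c(=O)c2[nH]cnc21` gives 11400 nM.
Compound 2 `CCCn1c(=O)n(C)c(=O)c2c1ncn2CCN(C)C` gives > 200000 nM.

Compound 2 stands at a limit of the assay: its value is known only as the limit of > 200000 nM in this assay, at which 1 of the 2 values shown sits, so no number exists for it. Within the data shown here, compound 1 gives a number in this assay, but it is not a single-place change from compound 2, and no step between the two is given; the two values show only that compound 1 has a measured number while compound 2 does not.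

Compound 3, `CCCn1c(=O)n(C)c(=O)c2c1ncn2CCC(C)=O`, differs from compound 2 by acetyl in place of dimethylamino on a saturated chain carbon, two bonds along the chain from an aromatic nitrogen. Among the measured compounds shown here, with compound 2 known only as a limit, no measured step anchors the expectation. Compound 3 is expected to sit near that limit or somewhat below it, so the step from compound 2 to compound 3 is estimated at an at least 2.0-fold lower number from compound 2 to compound 3 (0.30 log units; that floor lies within the scatter), towards stronger inhibition if beyond the scatter at all. For compound 3 the estimate in this assay is 100000 nM, ranging from 25000 nM to 400000 nM.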

Compound 3, inhibition constant: 30000 nM
Estimate against measurement, compound 3: 3.3-fold (0.52 log units) above, within the range that was stated.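

In this assay, among these compounds, acetyl in place of dimethylamino on a saturated chain carbon, two bonds along the chain from an aromatic nitrogen, gives an at least 6.6-fold lower number from compound 2 to compound 3 (0.82 log units; beyond the scatter), so this place on the shared core now has a change whose direction can be read, which the earlier compounds did not offer. The size of that step is only a floor, as compound 2 is known solely as a limit: the limit of > 200000 nM in this assay, at which 1 of the 3 values shown sits. The two groups have the same count of heavy atoms and of hydrogen-bond acceptors, and neither carries a net charge, so the step does not follow from a difference in any of those counts.

The compounds shown leave open how far the true gap runs and whether the step reflects the loss of dimethylamino, the arrival of acetyl, or both. They also leave open how a carboxylic acid, a primary amine or a longer chain at this place would read in this assay, and whether the same exchange would give a step of similar size on another core.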